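A Methyl Added to the Aryl Sulfonamide of Compound 1

This account rests on a few compounds, and the source may have more. Where it says the series, first, only, none or still open, it means among the compounds named here.

Compound 1 `COc1cc2nc(Cl)nc(NS(=O)(=O)c3ccccc3)c2cc1OC` belongs to a small set examined in a functional assay on THP-1 cells (Homo sapiens) for cytotoxicity, read by MTT assay, with a stated time of 24 h; on this read-out higher numbers stand for weaker inhibition and lower numbers for stronger inhibition. In this assay compound 1 gives 8.17 ug/mL, the lowest of the three numbers recorded so far. Compound 2 `COc1cc2nc(N3CCCC3)nc(NS(=O)(=O)C3CC3)c2cc1OC` gives 9.13 ug/mL in this assay, a number that sits within the scatter of that of compound 1. Within the data shown here, compound 3 `COc1cc2nc(Cl)nc(NS(=O)(=O)c3cccc(C(F)(F)F)c3)c2cc1OC` gives 36.4 ug/mL in this assay; the step of a 4.5-fold higher number from compound 1 to compound 3 (0.65 log units; beyond the scatter) is modest but beyond the scatter, and it is the only measured step that alters the aryl sulfonamide shared by these compounds.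

Compound 4 `COc1cc2nc(Cl)nc(NS(=O)(=O)c3ccc(C)cc3)c2cc1OC` has not yet been measured in this assay. It differs from compound 1 in one place: methyl in place of hydrogen on an aromatic carbon The entering group sits para to a large group. Among the measured compounds shown here, the only measured step that bears on this change, a 4.5-fold higher number from compound 1 to compound 3 (0.65 log units; beyond the scatter), shows that a group entering the same ring raised the number, though that group was trifluoromethyl rather than methyl, so the evidence is indirect and a smaller shift seems reasonable. Compound 4 is therefore expected to give 12 ug/mL in this assay, with a range from 6 ug/mL to 30 ug/mL. The expected step of a 1.5-fold higher number from compound 1 to compound 4 (0.17 log units; within the scatter) is a slight rise, likely close to the edge of the scatter.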

Compound 4, half-maximal inhibitory concentration: 33.5 ug/mL
Compound 4: the middle estimate sits 2.8-fold (0.45 log units) below what was measured, and the stated range ends below it.
By their numbers in this assay, from the lowest: compounds 1 and 2 (each within the scatter of the next); then compounds 4 and 3 (each within the scatter of the next).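

In this assay, methyl in place of hydrogen on an aromatic carbon, para to a large group, gives a 4.1-fold higher number from compound 1 to compound 4 (0.61 log units; beyond the scatter) and so takes the number beyond the scatter, which shows that even this small group changes the read-out when phenyl becomes 4-methylphenyl. Until now the only measured change on this ring was the trifluoromethyl step, a 4.5-fold higher number from compound 1 to compound 3 (0.65 log units; beyond the scatter), so a rise could have been particular to that group, whereas these two steps now show higher numbers with two different groups and neither listed step on this ring goes against that direction. The data on hand offer no measurement that explains why methyl raises the number, and the rise stands here as an observation only.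

The compounds shown leave open whether an ethyl, a methoxy, an amine or a carboxylic acid on this same carbon would also raise the number, and so whether any group entering here does so or only some do. They also leave open whether methyl would have the same effect on another carbon of the ring, or in a compound carrying pyrrolidine in place of the chlorine of compound 1.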